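A few compounds are considered here, and "the series" means these few. Any claim that something is new, unique, unknown or untested is made for them only; others in the source may bear on it.

The compounds measured so far:
compound 1 `C=C1C(=O)O[C@@H]2[C@@H]3[C@@]4(C=C[C@@]3(C)[C@]3(C4)C(=O)O[C@@H]4[C@H]5C(C)=CC[C@H]5[C@](C)(O)C[C@H](O)[C@H]43)[C@](C)(O)CC[C@@H]12` — > 10000 nM, a limit of the assay
compound 2 `C/C=C(\C)C(=O)O[C@H]1C[C@@](C)(O)[C@]23C=C[C@](C)([C@@H]2[C@H]2OC(=O)[C@@H](C)[C@@H]21)[C@]1(C3)C(=O)O[C@@H]2[C@H]3C(C)=CC[C@H]3[C@](C)(O)C[C@H](O)[C@H]21` — 9900 nM
compound 3 `C=C1C(=O)O[C@H]2[C@H]1[C@@H](O)C[C@@](C)(O)[C@]13C=C[C@](C)([C@H]21)[C@]1(C3)C(=O)O[C@@H]2[C@H]3C(C)=CC[C@H]3[C@](C)(O)C[C@H](OC(=O)/C(C)=C\C)[C@H]21` — > 10000 nM, a limit of the assay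

All three were tested in a functional assay on CNE-2 cells (Homo sapiens) for cytotoxicity, read by MTT assay, with a stated time of 48 h; on this read-out lower numbers stand for stronger inhibition and higher numbers for weaker inhibition. For compound 1 the read-out is only a limit, > 10000 nM, and not a number. Compound 1 therefore stands at the limit of > 10000 nM in this assay, at which 2 of the 3 values shown sit, so it is no more than weakly cytotoxic on these cells, and the same holds for compound 3. Compound 2, which carries an ester of the same family, gives 9900 nM, a measured number that shows weak cytotoxicity on these cells.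

The unmeasured compound 4 `C=C1C(=O)O[C@@H]2[C@@H]3[C@@]4(C=C[C@@]3(C)[C@]3(C4)C(=O)O[C@@H]4[C@H]5C(C)=CC[C@H]5[C@](C)(O)C[C@H](OC(=O)/C(C)=C/C)[C@H]43)[C@](C)(O)CC[C@@H]12` arises from compound 1 by one change: (1-methylprop-1-en-1-yl)carbonyl in place of hydrogen on an oxygen on a saturated carbon. Read one bond further out, the hydroxy of compound 1 becomes ((1-methylprop-1-en-1-yl)carbonyl)oxy in compound 4. Compounds 2 and 3 already show that adding such an ester to this core leaves the read-out at or near the limit, so no step beyond the usual scatter is expected in this assay from compound 1 to compound 4, a step that the limit leaves unreadable from compound 1 to compound 4. Compound 4 is thus estimated at 12000 nM, with a range from 6000 nM to 30000 nM, and most likely the assay will again report only a limit.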

Compound 4, half-maximal inhibitory concentration: > 10000 nM
Compound 4: only a limit was reported; the forecaster's own chance of this, stated with the estimate: 70%; the middle value does not contradict the limit.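

For the compounds shown here, compound 1 and compound 4 each return only a limit of the assay in this assay and not a number, so no step between them can be read. The compounds shown leave open how much the ((1-methylprop-1-en-1-yl)carbonyl)oxy group changes the read-out, and whether any change to the shared core gives clearly stronger cytotoxicity.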